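Opening the Ring of Compound 2: An Expected Step

The source may hold more compounds than are shown below. What is called first, only, known or untested is meant among the compounds shown, and "the series" means these compounds.

Three compounds have been examined so far in a functional assay on KB cells (Homo sapiens) for inhibition, read by MTT assay, with a stated time of 24 h, tested at 10 ug/mL; on this read-out higher numbers stand for more inhibition of growth at the one concentration tested and lower numbers for less inhibition of growth. Compound 1 (`O=C(CCCCC1CCSS1)Nc1cccc(C(F)(F)F)c1`) gives 10.9% in this test, and compound 3 (`O=C(CCCCC(S)CCS)Nc1ccc(F)cc1`) gives 13.3% there, two values within the usual scatter of each other. Compound 2 (`O=C(CCCCC1CCSS1)Nc1ccc([N+](=O)[O-])c(C(F)(F)F)c1`) has no single number and stands on the record only as "not active" (no number reported) in the same test.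

Compound 4 (`O=C(CCCCC(S)CCS)Nc1ccc([N+](=O)[O-])c(C(F)(F)F)c1`) has not yet been measured. It departs from compound 2 in one place: a group of 5 heavy atoms (3 carbon, 2 sulfur; no ring) in place of a group of 5 heavy atoms (3 carbon, 2 sulfur; one five-membered non-aromatic ring with 2 hetero atoms), on a saturated chain carbon, four bonds along the chain from a carbonyl carbon. The one five-membered non-aromatic ring leaves and a 1,3-disulfanylpropyl enters, on a saturated chain carbon, four bonds along the chain from a carbonyl carbon.

For the measured compounds named here, no measured pair isolates this change. Compound 3 carries the 1,3-disulfanylpropyl and compound 1 carries the ring, but they also differ elsewhere, so the values of compound 3 (13.3%) and compound 1 (10.9%) offer only a rough guide. From this, no step beyond the scatter is expected in this assay, though any small movement would more likely be upward from compound 2. Compound 4 is expected to show weak growth inhibition, estimated at 12% (expected range 0% to 30%).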

Compound 4, percent growth inhibition at one concentration: 4.04%
Beside the measured number, compound 4's estimate is 8 percentage points above it, within the range that was stated.
By their numbers in this assay, from the lowest: compounds 4, 1 and 3 (each within the scatter of the next).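

In this assay, for the compounds shown here, compound 2 has no single number, so no step from it to compound 4 can be read, although compound 4 gives 4.04%. The compounds shown leave open whether replacing the five-membered ring with 1,3-disulfanylpropyl changes growth inhibition on this core. No other data shown here bear on this result.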